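The source may hold more compounds than are shown below. What is called first, only, known or untested is meant among the compounds shown, and "the series" means these compounds.

Measured in a functional assay on A2780 cells (Homo sapiens) for antiproliferative activity, read by MTT assay, with a stated time of 48 h; a lower number here means a stronger inhibitor, a higher number a weaker inhibitor:
Compound 1 `COc1ccc(C(=O)c2cc(OC)c(OC)c(OC)c2)c(NC(=O)CO)c1` gives 100 nM
Compound 2 `C=C(c1ccc(OC)cc1NC(=O)CO)c1ccc(OC)c2c1OC(C)(C)C=C2` gives 40 nM
Compound 3 `C=C(c1ccc(OC)cc1NC(=O)CN)c1ccc(OC)c2c1OC(C)(C)C=C2` gives 80 nM

Compound 3, at 80 nM, cannot be told apart from compound 1 or compound 2, as its value lies within the usual scatter of both.

The next compound, compound 4 `C=C(c1ccc(OC)cc1NC(=O)CNC)c1ccc(OC)c2c1OC(C)(C)C=C2`, carries methyl in place of hydrogen on an amine nitrogen. Within the data shown here, only one measured step bears on this change: amino in place of hydroxy on a saturated chain carbon bound to a carbonyl carbon (a 2.0-fold higher number from compound 2 to compound 3 (0.30 log units; within the scatter)). That step stayed within the scatter, but it is a different swap, so it is only a weak guide. Among the measured compounds shown here, no measured compound shows the effect of methyl on this nitrogen, so no clear shift in either direction is expected in this assay.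

The expected step is therefore none beyond the scatter (no change at the digits printed from compound 3 to compound 4 (within the scatter)). For compound 4 the estimate is 80 nM, with an expected range from 30 nM to 220 nM.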

Compound 4, half-maximal inhibitory concentration: 210 nM
Beside the measured number, compound 4's estimate is 2.6-fold (0.42 log units) below it; low and high end bracket the measured number.
By their numbers in this assay, from the lowest: compounds 2, 3 and 1 (each within the scatter of the next, the first and the last beyond it); then compound 4.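

In this assay, one methyl on the amine nitrogen is enough to produce a step beyond the scatter (a 2.6-fold higher number from compound 3 to compound 4 (0.42 log units; beyond the scatter)), so this nitrogen does not tolerate every change without a cost, even though the step is modest. Measured against the hydroxy group, the methylamino group gives a larger step (a 5.3-fold higher number from compound 2 to compound 4 (0.72 log units; beyond the scatter)), whereas the plain amino group stayed within the scatter of hydroxy. No measurement at hand explains why the added methyl weakens the compound.

From the compounds shown here alone, it remains open whether an ethyl group on this nitrogen, a dimethylamino group or a carboxylic acid at the chain end would continue this trend. Going by these compounds, it is also open whether the same methyl swap would act alike on the core of compound 1.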